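The compounds below may be only part of what the source reports. "The series", "measured", "known", "first", "only" and "open" are said of these compounds alone.

Compound 1 `O=[N+]([O-])c1ccc(-c2nnc(SCCCN3CCN(c4nc5ccccc5o4)CC3)o2)cc1` is the reference point of this small set. In a functional assay on HepG2 cells (Homo sapiens) for inhibition, read by MTT assay, with a stated time of 72 h (on this read-out higher numbers stand for weaker inhibition and lower numbers for stronger inhibition), compound 1 gives 67200 nM. Its two companions carry other substituents on the same aryl ring: compound 2 `Fc1ccc(-c2nnc(SCCCN3CCN(c4nc5ccccc5o4)CC3)o2)cc1` gives 83800 nM and compound 3 `Brc1ccc(-c2nnc(SCCCN3CCN(c4nc5ccccc5o4)CC3)o2)cc1` gives 67500 nM. All three numbers lie within the scatter of one another, so compound 1 cannot be set apart from the other two; the steps of a 1.2-fold higher number from compound 1 to compound 2 (0.10 log units; within the scatter), a 1.0-fold higher number from compound 1 to compound 3 (0.00 log units; within the scatter) and a 1.2-fold lower number from compound 2 to compound 3 (0.09 log units; within the scatter) are each within the scatter.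

Compound 4 `O=C(NCc1nnc(SCCCN2CCN(c3nc4ccccc4o3)CC2)o1)c1ccccc1` changes more than a substituent: benzamidomethyl in place of 4-nitrophenyl on an aromatic carbon. The measured steps all concern exchanges of one substituent on the aryl ring and say nothing directly about replacing that ring by a benzamidomethyl group, but they show this assay to be insensitive to change at that end of the molecule. A step of about a 1.0-fold higher number from compound 1 to compound 4 (0.02 log units; within the scatter) is therefore expected, that is, none beyond the scatter, with the range widened for the size of the change. Compound 4 is estimated at 70000 nM, between 25000 nM and 200000 nM.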

Compound 4, half-maximal inhibitory concentration: 88900 nM
For compound 4 the middle estimate is 1.3-fold (0.10 log units) below the measured one; low and high end bracket the measured number.
By their numbers in this assay, from the lowest: compounds 1, 3, 2 and 4 (each within the scatter of the next).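

In this assay the steps of a 1.3-fold higher number from compound 1 to compound 4 (0.12 log units; within the scatter) and a 1.3-fold higher number from compound 3 to compound 4 (0.12 log units; within the scatter) and a 1.1-fold higher number from compound 2 to compound 4 (0.03 log units; within the scatter) show that benzamidomethyl on this aromatic carbon cannot be told apart from any of the three aryl groups. The lack of a readable difference therefore extends beyond exchanges of one substituent on the aryl ring to replacement of the whole group, including a change that brings in the amide hydrogen as a hydrogen-bond donor where 4-nitrophenyl has none. Nothing at hand bears on why this position shows so little difference.

The compounds shown leave open whether any group on this aromatic carbon can move the number beyond the scatter. A carboxylic acid, an amine or a simple methyl group there might or might not behave like these four.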